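The source may hold more compounds than are shown below. What is called first, only, known or untested is meant among the compounds shown, and "the series" means these compounds.

Compound 1 `Cc1cccc(CSc2ncnc3c2ncn3[C@@H]2O[C@H](CO)[C@@H](O)[C@H]2O)c1`: 16.2 nM
Compound 2 `Cc1ccc(CSc2ncnc3c2ncn3[C@@H]2O[C@H](CO)[C@@H](O)[C@H]2O)cc1`: 15.1 nM

In an assay on isolated protein for inhibition of Equilibrative nucleoside transporter 1 (Homo sapiens) (on this read-out higher numbers stand for weaker inhibition and lower numbers for stronger inhibition), compound 1 gives 16.2 nM and compound 2 gives 15.1 nM. The two sit within the scatter of each other, separated only by a 1.1-fold lower number from compound 1 to compound 2 (0.03 log units; within the scatter), so compound 2 stands alongside compound 1 rather than apart from it. Compound 3 `OC[C@H]1O[C@@H](n2cnc3c(SCc4ccc(Cl)cc4Cl)ncnc32)[C@H](O)[C@@H]1O` has not yet been measured in this assay. It differs from compound 2 by 2,4-dichlorophenyl in place of 4-methylphenyl on a saturated chain carbon bound to a sulfur. Among the compounds with values here, the single measured step that touches this part of the molecule, from compound 1 to compound 2, shifted a methyl on the same ring and gave a 1.1-fold lower number from compound 1 to compound 2 (0.03 log units; within the scatter). Within the data shown here, no measured pair shows what chlorine on this ring does, so the expectation rests on that one quiet step alone. The expected step is a 1.0-fold lower number from compound 2 to compound 3 (0.00 log units; within the scatter). Compound 3 is therefore estimated at 15 nM in this assay, with a range from 5 nM to 50 nM.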

Compound 3, inhibition constant: 4.37 nM
Compound 3: middle estimate off by 3.4-fold (0.54 log units), on the high side; measured number outside the range, below it.
By their numbers in this assay, from the lowest: compound 3; then compounds 2 and 1 (each within the scatter of the next).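

In this assay, the group on the saturated chain carbon bound to a sulfur can move the number beyond the scatter: 2,4-dichlorophenyl gives a clear change against both methyl compounds (a 3.5-fold lower number from compound 2 to compound 3 (0.54 log units; beyond the scatter); a 3.7-fold lower number from compound 1 to compound 3 (0.57 log units; beyond the scatter)). The earlier pair, with its methyl in two places on the ring, stayed within the scatter and gave no sign that this position responds to change at all. Nothing available accounts for the stronger inhibition seen with the 2,4-dichlorobenzyl group.

The compounds shown leave open whether one chlorine alone would give the same step, since compound 3 carries two and has also lost the methyl; a phenyl ring with a single chlorine is not among them. Going by these compounds, how a methoxy group on this ring, or a longer chain in place of the chain carbon, would read also remains open.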